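Swapping a pyrrole for a chlorofuran on a cyanoacrylamide

This account rests on a few compounds, and the source may have more. Where it says the series, first, only, none or still open, it means among the compounds named here.

Of the compounds shown here, three have been tested in a functional assay on MCF7 cells (Homo sapiens) for inhibition, read by MTT assay, with a stated time of 72 h; on this read-out higher numbers stand for weaker inhibition of growth and lower numbers for stronger inhibition of growth. Compound 1 `N#C/C(=C\c1c[nH]c2ccccc12)C(=O)c1c[nH]c2ccccc12` gives 11000 nM. Compound 2 `COc1ccc(CNC(=O)/C(C#N)=C/c2ccc[nH]2)cc1` gives 34000 nM. Compound 3 `N#C/C(=C\c1ccco1)C(=O)NCc1ccc(Cl)c(Cl)c1` gives 20000 nM. On these numbers compound 2 stands above compound 1 by a margin that is beyond the usual scatter, so compound 1 inhibits growth more strongly, while compound 2 and compound 3 lie within the scatter of each other and cannot be ranked.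

Compound 4 `COc1ccc(CNC(=O)/C(C#N)=C/c2ccc(Cl)o2)cc1` has not yet been measured in this assay. It differs from compound 2 in one place: 5-chlorofuran-2-yl in place of 1H-pyrrol-2-yl on a double-bonded chain carbon bound to a double-bonded chain carbon. Among the measured compounds shown here, no measured pair shows this exact exchange, and compound 3, which carries a plain furan ring with a different amide end, offers no direct comparison. With nothing to anchor a larger move, the expected step from compound 2 to compound 4 is a 1.4-fold lower number from compound 2 to compound 4 (0.13 log units; within the scatter), in whichever direction, within the scatter. On that basis compound 4 is estimated at 25000 nM, with a plausible range from 8000 nM to 70000 nM.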

Compound 4, concentration for 50% growth inhibition: 9000 nM
For compound 4 the middle estimate is 2.8-fold (0.44 log units) above the measured one, within the range that was stated.
By their numbers in this assay, from the lowest: compounds 4, 1, 3 and 2 (each within the scatter of the next, the first and the last beyond it).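

With the rest of compound 2 unchanged, 5-chlorofuran-2-yl in place of 1H-pyrrol-2-yl gives a 3.8-fold lower number from compound 2 to compound 4 (0.58 log units; beyond the scatter) in this assay, so growth inhibition is stronger after the exchange. Among the compounds shown here, this is the first single-place comparison in the set, and it shows that the ring on this double-bonded chain carbon can shift the read-out by a modest step beyond the scatter. The exchange removes a hydrogen-bond donor and adds a hydrogen-bond acceptor and a chlorine, but no measurement here ties the step to any of these differences.

The ring and the chlorine change together, so these compounds leave open how much of the step belongs to each. Going by these compounds, a methyl or a bromine in place of the chlorine would help separate them, and whether the step holds with a different amide end also remains open.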